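A Phenyl for a 1-Chloroethyl: Expected Cell Toxicity

The source may hold more compounds than are shown below. What is called first, only, known or untested is meant among the compounds shown, and "the series" means these compounds.

Compound 3 `COc1ccc(C(=O)Nc2ccccc2)cc1NC(=O)C(C)Cl` was measured in an ADME assay on MDCK cells (Canis lupus familiaris) for cytotoxicity, read by cytopathic effect, with a stated time of 48 h (on this read-out lower numbers stand for higher toxicity in this test and higher numbers for lower toxicity in this test), where compound 3 gives 200 uM. Among the numbers given, compound 3 stands lowest; its nearest neighbour is compound 1 `CCC(=O)Nc1cc(C(=O)Nc2cccc(Cl)c2)ccc1OC`, which in this assay gives 602 uM, a gap that lies beyond the usual scatter. Compound 2 `CCC(=O)Nc1cc(C(=O)NC2CCC2)ccc1OC` in this assay reaches only a limit, > 724 uM. Among the compounds with values here, the single one-point step among the measured compounds, an at least 1.2-fold higher number from compound 1 to compound 2 (0.08 log units; that floor lies within the scatter), concerns a group on the amide-type nitrogen, and the limit of > 724 uM in this assay, at which 1 of the 3 values shown sits, is the only evidence on it.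

Compound 4 `COc1ccc(C(=O)Nc2ccccc2)cc1NC(=O)c1ccccc1` is not yet measured. It differs from compound 3 by phenyl in place of 1-chloroethyl on a carbonyl carbon. Within the data shown here, no measured step touches the carbonyl carbon, so the step from compound 1 to compound 2 does not bear directly on this change; it shows only that a change elsewhere moved the number upward, if at all, by an amount at the floor of the scatter. The expectation for compound 4 rests mainly on compound 3 standing lowest with 200 uM, which leaves more room upward than downward. For compound 4 the expected step is a 2.0-fold higher number from compound 3 to compound 4 (0.30 log units; within the scatter), an estimated move toward the other compounds. Compound 4 is therefore expected to give 400 uM in this assay, within a range of 150 uM to 800 uM.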

Compound 4, half-maximal toxic concentration: 193 uM
Compound 4: the middle estimate sits 2.1-fold (0.32 log units) above what was measured; measured number inside the range.
By their numbers in this assay, from the lowest: compounds 4 and 3 (each within the scatter of the next); then compound 1. At a limit, above all of these: compound 2.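

In this assay, within the data shown here, the only measured step at this place gives a 1.0-fold lower number from compound 3 to compound 4 (0.02 log units; within the scatter), with phenyl in place of 1-chloroethyl on a carbonyl carbon whose other neighbour is the amide-type nitrogen. The earlier compounds shown here said nothing about this position, and this pair shows that it accepts a swap from an open group of 3 heavy atoms carrying chlorine to an aromatic ring of 6 carbon atoms while the two numbers stay within the scatter of each other, so the chlorine of the 1-chloroethyl group is not required for a number at this level. The only other information available concerns the limit reached by compound 2, which lies at a different place in the structure, so nothing shown here offers an explanation for this result.

Going by these compounds, it remains open whether an amine, a carboxylic acid or a longer chain on this carbonyl carbon would fit the same picture. On these data alone, it is also open whether this step would read the same with 3-chlorophenyl or cyclobutyl on the other amide-type nitrogen, the groups that compound 1 and compound 2 carry there.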